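The source may report more compounds than this note shows. Statements on the series, on what has been measured and on what is new or still open speak of the compounds shown alone.

Compound 1, `COc1ccc(/C=C/S(=O)(=O)Cc2ccc(OC)cc2)cc1`, in a functional assay on BT-20 cells (Homo sapiens) for antiproliferative activity, read by trypan blue exclusion; a higher number here means a weaker inhibitor, a lower number a stronger inhibitor: > 20000 nM, which is a limit of the assay and not a number.
Compound 2, `COc1ccc(CS(=O)(=O)/C=C/c2ccc(Cl)cc2)cc1`: 2000 nM.
Compound 3, `COc1ccc(CS(=O)(=O)/C=C/c2ccc([N+](=O)[O-])cc2)cc1`: 5000 nM.

Compound 1 sits at the limit of > 20000 nM in this assay, at which 1 of the 3 values shown sits. Of the two compounds that give a number, compound 3 has the higher one, and so is the weaker inhibitor of the two; the gap is a 2.5-fold higher number from compound 2 to compound 3 (0.40 log units; beyond the scatter). Against compound 1 the step is an at least 4.0-fold lower number from compound 1 to compound 3 (0.60 log units; beyond the scatter), and the step of an at least 10-fold lower number from compound 1 to compound 2 (1.00 log units; beyond the scatter) goes the same way.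

The next compound, compound 4, is `COc1ccc(CS(=O)(=O)/C=C/c2ccc(N)cc2)cc1`. It differs from compound 3 in one place: amino in place of nitro on an aromatic carbon. Among the compounds with values here, no measured step carries an amino group, so the two steps that end at compound 3 are the only guide, and they point in opposite directions: the step of an at least 4.0-fold lower number from compound 1 to compound 3 (0.60 log units; beyond the scatter) lowered the number, while the step of a 2.5-fold higher number from compound 2 to compound 3 (0.40 log units; beyond the scatter) raised it. Each substituent at this position has given its own number, with no trend to lean on, so the expected direction for compound 4 is open and the expected step is a 1.6-fold higher number from compound 3 to compound 4 (0.20 log units; within the scatter), with a wide range. Compound 4 is estimated to give 8000 nM, between 2000 nM and 30000 nM.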

Compound 4, half-maximal inhibitory concentration: > 20000 nM
Compound 4: only a limit was reported; the forecaster's own chance of this, stated with the estimate: 25%; at least 2.5-fold (0.39 log units) between middle value and limit.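

In this assay, putting amino in place of nitro on this aromatic carbon, para to a large group, gives an at least 4.0-fold higher number from compound 3 to compound 4 (0.60 log units; beyond the scatter), and putting amino in place of chloro gives an at least 10-fold higher number from compound 2 to compound 4 (1.00 log units; beyond the scatter). The earlier compounds shown here showed only that the two replacements of methoxy tried so far, chloro and nitro, each gave a measurable number; amino shows that a replacement of methoxy here can also fail to do so, so the outcome at this position depends strongly on which group sits there. Compound 4 gives only a limit, the same limit as compound 1, and the step between these two compounds cannot be read: the limit of > 20000 nM in this assay, at which 2 of the 4 values shown sit.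

Going by these compounds, how much weaker compound 1 and compound 4 really are stays unknown, and so does any order between them. Also open, on these data alone, is whether an acetamide, which keeps the nitrogen but carries a carbonyl on it, or a small halogen such as fluoro, would give a number near those of the chloro and nitro compounds or would also end at the limit.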